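Branching the ester chain: propyl to isopropyl

A few compounds are considered here, and "the series" means these few. Any claim that something is new, unique, unknown or untested is made for them only; others in the source may bear on it.

Measured compounds:
compound 1 `CCOC(=O)C(Cn1ccnc1)NC(=O)c1c(C)nn(-c2ccccc2)c1Cl`: 600 nM
compound 2 `CCCOC(=O)C(Cn1ccnc1)NC(=O)c1c(C)nn(-c2ccccc2)c1Cl`: 620 nM

In an assay on HL-60 cells for inhibition of cytochrome P450 26A1 (Homo sapiens), read by HPLC, using microsomes and NADPH, with a stated time of 30 min (on this read-out higher numbers stand for weaker inhibition and lower numbers for stronger inhibition), compound 1 gives 600 nM and compound 2 gives 620 nM. Compound 2 holds the higher of the two numbers, but the step of a 1.0-fold higher number from compound 1 to compound 2 (0.01 log units; within the scatter) lies within the scatter. Compound 3 `Cc1nn(-c2ccccc2)c(Cl)c1C(=O)NC(Cn1ccnc1)C(=O)OC(C)C` differs from compound 2 by isopropyl in place of propyl on an oxygen next to a carbonyl group. Within the data shown here, the one measured step, a 1.0-fold higher number from compound 1 to compound 2 (0.01 log units; within the scatter), also changed only the ester chain and moved nothing beyond the scatter, so for compound 3 the expected step is a 1.0-fold higher number from compound 2 to compound 3 (0.02 log units; within the scatter). Compound 3 is therefore estimated at 650 nM, in the range 300 nM to 1400 nM.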

Compound 3, half-maximal inhibitory concentration: 460 nM
Beside the measured number, compound 3's estimate is 1.4-fold (0.15 log units) above it; measured number inside the range.
By their numbers in this assay, from the lowest: compounds 3, 1 and 2 (each within the scatter of the next).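

Branching the ester chain leaves the number within the scatter, both for isopropyl against propyl (a 1.3-fold lower number from compound 2 to compound 3 (0.13 log units; within the scatter)) and for the step from the ethyl ester (a 1.3-fold lower number from compound 1 to compound 3 (0.12 log units; within the scatter)). On this oxygen, therefore, the unbranched and branched chains shown cannot be told apart by this read-out. No measurement shown here bears on the cause of these small differences.

Still open, as far as these compounds go, is whether a longer chain such as butyl, or a bulkier one such as tert-butyl, would stay within the scatter. A carboxylic acid or an amide in place of the ester also remains untested among the compounds shown.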